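This account rests on a few compounds, and the source may have more. Where it says the series, first, only, none or still open, it means among the compounds named here.

The measured compounds:
Compound 1 `COc1ncnc2c1c(-c1ccsc1)cn2[C@@H]1O[C@H](CO)[C@@H](O)[C@H]1O`: in a functional assay on HeLa S3 cells (Homo sapiens) for antiproliferative activity, read by XTT assay, with a stated time of 72 h (a lower number here means a stronger inhibitor, a higher number a weaker inhibitor), compound 1 gives 3350 nM.
Compound 2 `COc1nc(N)nc2c1c(-c1ccsc1)cn2[C@@H]1O[C@H](CO)[C@@H](O)[C@H]1O`: in this assay compound 2 gives > 20000 nM, a limit of the assay rather than a number.
Compound 3 `O=c1[nH]cnc2c1c(-c1ccccc1)cn2[C@@H]1O[C@H](CO)[C@@H](O)[C@H]1O`: in this assay compound 3 gives > 20000 nM, likewise a limit of the assay.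

Compound 2 arises from compound 1 by amino in place of hydrogen on an aromatic carbon, and that step gave an at least 5.9-fold higher number from compound 1 to compound 2 (0.77 log units; beyond the scatter). Compound 4 `Nc1nc2c(c(-c3ccccc3)cn2[C@@H]2O[C@H](CO)[C@@H](O)[C@H]2O)c(=O)[nH]1`, not yet measured, arises from compound 3 by amino in place of hydrogen on an aromatic carbon. The surroundings differ: in compound 1 the place is meta to a methoxy group (2 heavy atoms), in compound 3 meta to a group of 1 heavy atom, so this is the same kind of change, not the same. How the cores of compound 1 and compound 3 differ is not broken down here.

Because the limit of > 20000 nM in this assay, at which 2 of the 3 values shown sit, already holds compound 3, and because an at least 5.9-fold higher number from compound 1 to compound 2 (0.77 log units; beyond the scatter) went toward weaker inhibition, compound 4 is expected to remain at that limit. The expected step is a step that the limit leaves unreadable from compound 3 to compound 4. Compound 4 is estimated at 40000 nM, between 15000 nM and 150000 nM.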

Compound 4, half-maximal inhibitory concentration: > 20000 nM
Compound 4 gave a limit, no number (the forecaster's own chance of this, stated with the estimate: 85%); the middle value lies beyond the limit too.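

Compound 3 and compound 4 both give a limit rather than a number, so no step can be read between them: the limit of > 20000 nM in this assay, at which 3 of the 4 values shown sit. From the compounds shown here alone, what amino in place of hydrogen does on the core of compound 3 stays open.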